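The source may hold more compounds than are shown below. What is called first, only, known or untested is meant among the compounds shown, and "the series" means these compounds.

Measured compounds:
Compound 1 `COc1ccc(-c2cc(/C=C/C(=O)c3ccc(N)cc3)[nH]n2)cc1` gives 7000 nM in a functional assay on MDA-MB-435 cells (Homo sapiens) for inhibition, read by sulforhodamine B assay, with a stated time of 48 h; a lower number here means a stronger inhibitor of growth, a higher number a weaker inhibitor of growth.
Compound 2 `COc1cc(-c2cc(/C=C/C(=O)c3ccc(N)cc3)[nH]n2)cc(OC)c1OC` gives 3210 nM in this assay.

Compound 2 stands at the lower of the two numbers; the nearest is compound 1, whose number is higher by a margin beyond the usual scatter. Compound 3 `COc1ccc(-c2cc(/C=C/C(=O)c3ccc(N)cc3)[nH]n2)cc1OC` has not yet been measured in this assay. It differs from compound 2 in one place: hydrogen in place of methoxy on an aromatic carbon. Compound 3 thus sits between compound 2 and compound 1 in how many methoxy groups that ring carries. Going by the values given here, no step between measured compounds is available, so only the two values can guide a guess; they show that the more heavily methoxylated compound 2 gives the lower number. Taking one methoxy away from compound 2 is therefore expected to raise the number somewhat, toward that of compound 1, though the step may be small enough to fall within the scatter. Compound 3 is estimated at 4500 nM, within 2500 nM to 8500 nM. That corresponds to an expected step of a 1.4-fold higher number from compound 2 to compound 3 (0.15 log units; within the scatter).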

Compound 3, concentration for total growth inhibition: 7230 nM
Beside the measured number, compound 3's estimate is 1.6-fold (0.21 log units) below it; the range from low to high includes it.
By their numbers in this assay, from the lowest: compound 2; then compounds 1 and 3 (each within the scatter of the next).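

Hydrogen in place of the methoxy on the aromatic carbon ortho to a methoxy group and meta to a large group weakens growth inhibition in this assay: the result is a 2.3-fold higher number from compound 2 to compound 3 (0.35 log units; beyond the scatter) and this counts as a modest change. Methoxy in place of hydrogen, in contrast, gives a 1.0-fold higher number from compound 1 to compound 3 (0.01 log units; within the scatter) and so makes no real difference. Among these three compounds, the second methoxy, in compound 3, therefore brings no gain, whereas the third, in compound 2, does.

Nothing available explains why these two steps differ. On these data alone, it remains open whether a hydroxyl group or a chlorine atom on this carbon would match the methoxy of compound 2, and whether the same step would hold with the amine on the other ring replaced.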